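The compounds below may be only part of what the source reports. "The series", "measured", "known", "first", "only" and "open" are said of these compounds alone.

Measured compounds:
Compound 1, `Fc1ccc2nc(-c3cc(-c4ccccc4)nn3-c3ccccc3)ccc2c1`: 126%
Compound 2, `COc1ccc(-c2cc(-c3ccc4cc(F)ccc4n3)n(-c3ccccc3)n2)cc1`: 104%

In an ADME assay on Huh-7 cells (Homo sapiens) for cytotoxicity, read by XTT assay, with a stated time of 3 days, tested at 20 uM (on this read-out lower numbers stand for a stronger effect and higher numbers for a weaker effect at the one concentration tested), compound 1 gives 126%, the highest of the two numbers shown, and compound 2 gives 104%. Among the compounds with values here, the only step between measured compounds is a number 22 percentage points lower from compound 1 to compound 2 (beyond the scatter), a methoxy in place of hydrogen on an aromatic carbon, and it moves the read-out only modestly despite lying beyond the scatter.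

Compound 3, `Fc1ccc(-n2nc(-c3ccccc3)cc2-c2ccc3cc(F)ccc3n2)cc1`, differs from compound 1 in one place: fluoro in place of hydrogen on an aromatic carbon. Cut one bond further out, the same difference reads as phenyl to 4-fluorophenyl, para to a large group. Within the data shown here, no measured step introduces a fluoro, so the step from compound 1 to compound 2 is the only guide, and it concerns a different group on a different ring. It suggests that a single small substituent on an outer phenyl ring shifts this assay by a modest amount at most. The expected step is therefore a number 11 percentage points lower from compound 1 to compound 3 (beyond the scatter), small and more likely downward than upward. For compound 3 the estimate is 115%, with a range from 90% to 138%.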

Compound 3, a percentage reported as activity, at one concentration (the size of the read-out at that concentration, not a potency): 97.8%
The estimate for compound 3 lay 17.2 percentage points above the measured number; the range from low to high includes it.
By their numbers in this assay, from the lowest: compounds 3 and 2 (each within the scatter of the next); then compound 1.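

In this assay, the change from phenyl to 4-fluorophenyl gives a number 28.2 percentage points lower from compound 1 to compound 3 (beyond the scatter) and so shows that a single fluoro, para to a large group on a six-membered aromatic ring of carbon only, is enough to move the read-out beyond the scatter. Until now, the only evidence on substitution was the methoxy change, a number 22 percentage points lower from compound 1 to compound 2 (beyond the scatter) on a different ring, and the two steps now show that a single substituent at either of these two places lowers the number relative to compound 1, with no listed step going the other way. Nothing available bears on why the fluoro change has this effect.

Going by these compounds, it remains open whether a quite different group at this same place, such as an amine or a carboxylic acid, would lower the number as the fluoro does or would raise it instead. Also open, on these data alone, is whether the fluoro and the methoxy, carried together on the core of compound 1, would lower the number further than either does alone.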